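This account rests on a few compounds, and the source may have more. Where it says the series, first, only, none or still open, it means among the compounds named here.

Of the compounds shown here, three have been measured in a functional assay on SMMC-7721 cells (Homo sapiens) for inhibition, read by CCK-8 assay, with a stated time of 72 h, tested at 2 uM; on this read-out higher numbers stand for more inhibition of growth at the one concentration tested and lower numbers for less inhibition of growth. Compound 1, `Nc1ccccc1NC(=O)/C=C/c1ccc(CSc2ccc(Cl)cc2)cc1`, gives 15.2% in this assay. Compound 2, `Nc1ccccc1NC(=O)c1ccc(CSc2ccc(C(F)(F)F)cn2)cc1`, gives 12.4% in this assay, a number that lies within the scatter of the result for compound 1. Compound 3, `CCc1ccc(SCc2ccc(C(=O)Nc3ccccc3N)cc2)cc1`, gives 25.7% in this assay, and here the gap to compound 1 goes beyond the scatter, so compound 1 sits clearly below compound 3 while it cannot be told apart from compound 2. All three results stay in the lower part of the scale.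

Compound 4, `Nc1ccccc1NC(=O)/C=C/c1ccc(CSCCc2ccccc2)cc1`, has not yet been measured. It differs from compound 1 in one place: phenethyl in place of 4-chlorophenyl on a sulfur. Seen one bond further out, the change reads (4-chlorophenyl)sulfanyl to phenethylsulfanyl.

For the measured compounds named here, no pair of measured compounds differs in exactly this way, so no measured step guides the expectation. Given that the three measured compounds all fall in a narrow low band, the step of a number 1.8 percentage points higher from compound 1 to compound 4 (within the scatter) is expected to be small and to remain within the usual scatter. Compound 4 is therefore estimated to give 17% in this assay, with a plausible range from 5% to 30%.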

Compound 4, percent growth inhibition at one concentration: 14.7%
For compound 4 the middle estimate is 2.3 percentage points above the measured one, within the range that was stated.
By their numbers in this assay, from the lowest: compounds 2, 4 and 1 (each within the scatter of the next); then compound 3.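

In this assay, for the compounds shown here, putting phenethyl in place of 4-chlorophenyl on a sulfur gives a number 0.5 percentage points lower from compound 1 to compound 4 (within the scatter), the first direct reading of a change at this place in the shared core. The step shows that this exchange, in which the chlorine leaves and the aromatic ring of carbon only now stands on a saturated chain, cannot be told apart from no change at the one concentration tested, so the two groups read alike here and neither can be ranked above the other. Nothing available explains why these two groups give results that cannot be told apart.

The compounds shown leave open whether an amine or a carboxylic acid at the end of the group on the sulfur, or a chain longer than phenethyl, would give a step beyond the scatter from compound 1. They also leave open whether the same exchange of 4-chlorophenyl for phenethyl would read alike on a different core, since this single step comes from one pair of compounds in one assay.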